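Working notes: from compound 2 to compound 4

The source may hold more compounds than are shown below. What is called first, only, known or untested is meant among the compounds shown, and "the series" means these compounds.

Measured so far:
- compound 1 `O=C(c1nn(-c2ccccc2)c2c1CC(NCc1ccccc1)CC2)N1CCCCC1` gives 0.3%
- compound 2 `O=C(c1c2c(nn1-c1ccccc1)CCC(NCc1ccc(F)cc1)C2)N1CCCCC1` gives 7%
- compound 3 `CCCn1nc(C(=O)N(C)C)c2c1CCC(NCc1ccc(F)cc1)C2` gives 21%

All three values come from an ADME assay on microsomes from liver (Mus musculus) for metabolic stability, read by HPLC, using NADPH, with a stated time of 60 min, at 37 degrees C, tested at 10 uM; on this read-out higher numbers stand for a more stable compound and lower numbers for a less stable compound. Compound 2 (7%) lies within the scatter of compound 1 (0.3%), while compound 3 (21%) stands higher, beyond the scatter.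

Compound 4 `O=C(c1c2c(nn1-c1ccc(F)cc1)CCC(NCc1ccc(F)cc1)C2)N1CCCCC1` differs from compound 2 by fluoro in place of hydrogen on an aromatic carbon and so reads as phenyl to 4-fluorophenyl. Going by the values given here, no measured pair shows this change on its own, so the data offer no direct guide. The expected a number 4 percentage points higher from compound 2 to compound 4 (within the scatter) is a small rise that stays within the scatter. Compound 4 is estimated at 11% (expected range 3% to 28%).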

Compound 4, percent of the compound remaining: 25%
The estimate for compound 4 lay 14 percentage points below the measured number; low and high end bracket the measured number.
By their numbers in this assay, from the lowest: compounds 1 and 2 (each within the scatter of the next); then compounds 3 and 4 (each within the scatter of the next).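

Phenyl to 4-fluorophenyl is the only change in the series that can be read on its own, and this assay shows a number 18 percentage points higher from compound 2 to compound 4 (beyond the scatter) for it. This position on the aromatic ring therefore responds to a single fluoro in place of hydrogen, which compound 1, compound 2 and compound 3 could not show, since no two of them differ in one place. Nothing measured here gives a reason for the step.

On these data alone, whether chloro, methoxy or a nitrile at this position would read the same stays open, as does fluoro at the other carbons of that ring.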